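The source may report more compounds than this note shows. Statements on the series, on what has been measured and on what is new or still open speak of the compounds shown alone.

Measured compounds:
- compound 1 `Oc1ccc(-c2cc(-c3ccsc3)cc(-c3ccc(O)cc3)n2)cc1`, in an assay on isolated protein for inhibition of DNA topoisomerase 1 (Homo sapiens), with a stated time of 30 min, tested at 100 uM (on this read-out higher numbers stand for a stronger effect at the one concentration tested and lower numbers for a weaker effect), compound 1 gives 61.7%
- compound 2 `Oc1ccc(-c2cc(-c3ccccn3)cc(-c3ccccc3O)n2)cc1`, in this assay compound 2 gives 0.2%

Both compounds share the same core, and each carries two hydroxyphenyl groups together with a third aromatic group. Of the two numbers, compound 2 stands lowest: its value sits far below that of compound 1, and the gap between them lies beyond the usual scatter of repeated measurements. Among the compounds with values here, no step between compounds that differ in a single place is available, so no single change can be tied to that gap.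

Compound 3 `Oc1ccc(-c2cc(-c3ccccn3)cc(-c3ccc(O)cc3)n2)cc1` has not yet been measured. It is built from the same atoms as compound 2, joined differently: 4-hydroxyphenyl in place of 2-hydroxyphenyl on an aromatic carbon. After this change compound 3 carries the same pair of 4-hydroxyphenyl groups as compound 1, while keeping the pyridin-2-yl group of compound 2.

Within the data shown here, with only two measured values and no matched step to lean on, the expected change from compound 2 to compound 3 in this assay is uncertain, and the estimate is a rise of moderate size, a number 29.8 percentage points higher from compound 2 to compound 3 (beyond the scatter). Compound 3 is expected to give about 30%, within a range from 3% to 65%.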

Compound 3, a percentage reported as inhibition, at one concentration (the size of the read-out at that concentration, not a potency): 1.4%
Estimate against measurement, compound 3: 28.6 percentage points above; the whole stated range lies above it.
By their numbers in this assay, from the lowest: compounds 2 and 3 (each within the scatter of the next); then compound 1.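

Swapping 2-hydroxyphenyl for 4-hydroxyphenyl on the aromatic carbon next to the ring nitrogen gives, in this assay, a number 1.2 percentage points higher from compound 2 to compound 3 (within the scatter) and so makes no clear difference while the pyridin-2-yl group is present. The new compound also forms a true matched pair with compound 1, and pyridin-2-yl in place of thiophen-3-yl gives a number 60.3 percentage points lower from compound 1 to compound 3 (beyond the scatter) as a large step, so with the pair of 4-hydroxyphenyl groups held constant, the choice of this third aromatic group alone separates a clear effect from almost none. Nothing available here explains why this exchange has so large an effect.

The compounds shown leave open whether the 2-hydroxyphenyl and 4-hydroxyphenyl groups would also be interchangeable alongside thiophen-3-yl, since the swap has been read only alongside pyridin-2-yl. Going by these compounds, it also remains open how the effect would respond to other groups in the place of thiophen-3-yl, such as a plain phenyl ring, a furan-3-yl ring or a pyridin-3-yl ring, which would show whether the drop belongs to pyridin-2-yl in particular or to the loss of thiophen-3-yl.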